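The compounds below may be only part of what the source reports. "The series", "measured", "known", "first", "only" and "open" are said of these compounds alone.

Series notes. Compound 1 `O=[N+]([O-])c1cn2c(n1)OC[C@@H](OCc1cccc(-c3ccc(F)cc3)c1)C2` and compound 2 `O=[N+]([O-])c1cn2c(n1)OC[C@@H](OCc1cccc(-c3ccc(OC(F)(F)F)cc3)c1)C2` share one core; compound 3 `Cn1nc(-c2ccc(F)cc2)cc1CO[C@@H]1COc2nc([N+](=O)[O-])cn2C1` and compound 4 `Cn1nc(-c2ccc(OC(F)(F)F)cc2)cc1CO[C@@H]1COc2nc([N+](=O)[O-])cn2C1` share another, and the difference between the two cores is not broken down here. In an ADME assay on Vero cells (Chlorocebus sabaeus) for cytotoxicity, with a stated time of 72 h (on this read-out higher numbers stand for weaker inhibition and lower numbers for stronger inhibition), compound 1 gives > 128000 nM, which is a limit of the assay and not a number. In this assay compound 2 gives > 128000 nM, again a limit. The change between these two, (trifluoromethoxy in place of fluoro on an aromatic carbon), produced a step that the two limits leave unreadable from compound 1 to compound 2; with both values sitting at the limit of > 128000 nM in this assay, at which 3 of the 3 values shown sit, no size can be read for it. In this assay compound 3 gives > 128000 nM, also a limit. Compound 4 carries the same change relative to compound 3, namely (trifluoromethoxy in place of fluoro on an aromatic carbon), a change that occurs twice among the compounds here and at the same place in both pairs. Within the data shown here, for compound 4 the step expected is a step that the limit leaves unreadable from compound 3 to compound 4, an expectation that rests on the unreadable step that the two limits leave unreadable from compound 1 to compound 2 and on (the limit of > 128000 nM in this assay, at which 3 of the 3 values shown sit), where every value so far has sat. Among the measured compounds shown here, the estimate for compound 4 is therefore 160000 nM, with the expected outcome being that the assay again reports only a limit rather than a number; the range 100000 nM to 400000 nM is given for completeness, with no measured step in this set supporting any movement off the limit.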

Compound 4, half-maximal inhibitory concentration: > 128000 nM
Compound 4: no number, only a limit; the forecaster's own chance of this, stated with the estimate: 85%; the middle value does not contradict the limit.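

No size can be read for the trifluoromethoxy in place of fluoro change, either between compound 1 and compound 2 or between compound 3 and compound 4, because these are limits of the assay and not numbers: the limit of > 128000 nM in this assay, at which 4 of the 4 values shown sit.

The compounds shown leave open whether that change moves the half-maximal inhibitory concentration at all on either core, and in which direction.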